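Halobenzyl swap on the sulfur-linked arm: compound 3 to compound 4

The source may report more compounds than this note shows. Statements on the series, on what has been measured and on what is new or still open speak of the compounds shown alone.

Of the compounds shown here, three have been measured in an assay on isolated protein for inhibition of Alpha glucosidase (Homo sapiens), read by spectrophotometry, with stated times of 15 min and 30 min; on this read-out lower numbers stand for stronger inhibition and higher numbers for weaker inhibition. Compound 1 `Clc1ccccc1CSc1nc(-c2ccc(Br)cc2)cc(-c2cccc(Br)c2)n1` gives 19000 nM. Compound 2 `Cc1ccc(-c2cc(-c3cccc(Br)c3)nc(SCc3ccc(F)cc3)n2)cc1` gives 19000 nM, and compound 3 `Cc1ccc(-c2cc(-c3cccc(Br)c3)nc(SCc3cccc(F)c3)n2)cc1` gives 19000 nM. Compound 3 thus stands level with compound 1 and compound 2 at the digits shown, with no step to either that goes beyond the scatter. Among the measured compounds shown here, the only single-point step among the measured compounds is no change at the digits printed from compound 2 to compound 3 (within the scatter), 3-fluorophenyl in place of 4-fluorophenyl on a saturated chain carbon bound to a sulfur, which left the number where it was.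

Compound 4 `Cc1ccc(-c2cc(-c3cccc(Br)c3)nc(SCc3ccccc3Cl)n2)cc1` has not yet been measured. Its difference from compound 3 is 2-chlorophenyl in place of 3-fluorophenyl on a saturated chain carbon bound to a sulfur. Compound 1 also carries 2-chlorophenyl on the saturated chain carbon bound to a sulfur, and its value in this assay is not separated from that of compound 3. For the measured compounds named here, the step of no change at the digits printed from compound 2 to compound 3 (within the scatter) bears most directly on the change and was flat, so the present swap of one halophenyl for another at the same place has no measured precedent for a shift. For no change at the digits printed from compound 3 to compound 4 (within the scatter) no change beyond the scatter is therefore expected. Compound 4 is estimated at 19000 nM, with a range from 9500 nM to 38000 nM.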

Compound 4, half-maximal inhibitory concentration: 19000 nM
Compound 4: the middle estimate sits on the measured number at the digits printed; low and high end bracket the measured number.
By their numbers in this assay, from the lowest: compounds 1, 2, 3 and 4 (each within the scatter of the next).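

In this assay the arm on the saturated chain carbon bound to a sulfur stays flat when both the halogen and its ring position differ, not just the fluorine position: 2-chlorophenyl in place of 3-fluorophenyl gives no change at the digits printed from compound 3 to compound 4 (within the scatter) and 2-chlorophenyl in place of 4-fluorophenyl gives no change at the digits printed from compound 2 to compound 4 (within the scatter) on the same shared core. Compound 4 also gives the first single-place step away from this arm, with the 2-chlorobenzyl group held constant: methyl in place of bromo on an aromatic carbon gives no change at the digits printed from compound 1 to compound 4 (within the scatter) and so this second site is flat for this pair as well. No measurement on hand accounts for the identical values across these four compounds.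

As far as these compounds go, the arm is represented here only by halophenyl groups, so the effect of an unsubstituted benzyl group, a carboxylic acid on the ring or a longer chain before it remains open. At the aromatic carbon only methyl and bromo appear, which leaves a methoxy group or an amine at that place open too.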